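The source may report more compounds than this note shows. Statements on the series, on what has been measured and on what is new or still open speak of the compounds shown alone.

The series shares the core of compound 1 `O=C(O)c1ccc(C(=O)c2ccc(C(=O)c3ccccc3)cc2)cc1`, which in an assay on CHO cells for inhibition of 3-oxo-5-alpha-steroid 4-dehydrogenase 2 (Homo sapiens) (a lower number here means a stronger inhibitor, a higher number a weaker inhibitor), gives 40 nM. Compound 2 `O=C(O)c1ccc(C(=O)c2ccc(C(=O)c3ccc(Cl)cc3Cl)cc2)cc1` carries 2,4-dichlorophenyl in place of phenyl on a carbonyl carbon, and in this assay compound 2 gives 35 nM. The step of a 1.1-fold lower number from compound 1 to compound 2 (0.06 log units; within the scatter) is within the scatter, so adding the two chlorines in that arrangement produced nothing that can be read as a change. Among the compounds with values here, on the numbers so far compound 2 sits at the lower end of the two values, with compound 1 the nearest and within the scatter of it.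

Compound 3 `O=C(O)c1ccc(C(=O)c2ccc(C(=O)c3ccc(Cl)c(Cl)c3)cc2)cc1` remains to be measured. Its difference from compound 2 is 3,4-dichlorophenyl in place of 2,4-dichlorophenyl on a carbonyl carbon. Within the data shown here, only one measured step bears on this part of the molecule, a 1.1-fold lower number from compound 1 to compound 2 (0.06 log units; within the scatter), and it was within the scatter. Shifting one chlorine on the same ring is a smaller alteration than introducing both chlorines was, so in this assay no step beyond the scatter is expected in either direction. Compound 3 is therefore expected to give about 35 nM, in the range 15 nM to 80 nM. The expected step of no change at the digits printed from compound 2 to compound 3 (within the scatter) would lie within the scatter.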

Compound 3, inhibition constant: 35 nM
Estimate against measurement, compound 3: no gap at the digits printed; low and high end bracket the measured number.
By their numbers in this assay, from the lowest: compounds 2, 3 and 1 (each within the scatter of the next).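

In this assay, 3,4-dichlorophenyl in place of 2,4-dichlorophenyl on a carbonyl carbon gives no change at the digits printed from compound 2 to compound 3 (within the scatter), which shows that these two chlorine arrangements cannot be told apart here, something the earlier pair could not show. With a 1.1-fold lower number from compound 1 to compound 3 (0.06 log units; within the scatter) as well, phenyl, 2,4-dichlorophenyl and 3,4-dichlorophenyl at this place all stand within the scatter of one another, so a second dichlorophenyl pattern also yields no readable difference from the phenyl of compound 1. Nothing at hand offers an explanation for this flat result.

Still open, on these data alone, is whether this place remains as undiscriminating with groups other than chlorine, such as a methoxy group or an amine on the ring, or a longer alkyl chain in place of the ring. All three compounds also share the same carboxylic acid and both carbonyls, so the compounds shown say nothing about those parts of the shared core, for example about an amide or a nitrile in place of the carboxylic acid.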